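From azepane ring to open aminoethyl chain

This account rests on a few compounds, and the source may have more. Where it says the series, first, only, none or still open, it means among the compounds named here.

Measured in a functional assay on OCI-Ly10 cells (Homo sapiens) for cytotoxicity, read by CCK-8 assay, with a stated time of 72 h; a higher number here means a weaker inhibitor, a lower number a stronger inhibitor:
- compound 1 `Cn1cc(NC(=O)c2cnc3ccc(N[C@@H]4CCCNC4)nn23)c(C(F)F)n1`: 700 nM
- compound 2 `Cn1cc(NC(=O)c2cnc3ccc(N[C@@H]4CCNC4)nn23)c(C(F)F)n1`: 3600 nM
- compound 3 `Cn1cc(NC(=O)c2cnc3ccc(N[C@@H]4CCCCNC4)nn23)c(C(F)F)n1`: 800 nM

Compound 3 belongs to the lower pair of numbers. The two steps that place it are a 1.1-fold higher number from compound 1 to compound 3 (0.06 log units; within the scatter) and a 4.5-fold lower number from compound 2 to compound 3 (0.65 log units; beyond the scatter). Compound 4 `Cn1cc(NC(=O)c2cnc3ccc(NCCN)nn23)c(C(F)F)n1` is still unmeasured. It carries 2-aminoethyl in place of azepan-3-yl on a nitrogen on an aromatic ring. For the measured compounds named here, no measured step removes the ring, so the ring-size steps are the only guide. Going to the pyrrolidin-3-yl group cost a 5.1-fold higher number from compound 1 to compound 2 (0.71 log units; beyond the scatter), whereas the azepan-3-yl group cost nothing beyond the scatter. A modest rise of similar size is therefore expected, an estimated 3.8-fold higher number from compound 3 to compound 4 (0.57 log units; beyond the scatter). For compound 4 the estimated value is 3000 nM, with an expected range of 1000 nM to 10000 nM.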

Compound 4, half-maximal inhibitory concentration: 8800 nM
Compound 4: the middle estimate sits 2.9-fold (0.47 log units) below what was measured; low and high end bracket the measured number.
By their numbers in this assay, from the lowest: compounds 1 and 3 (each within the scatter of the next); then compound 2; then compound 4.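

In this assay, replacing the ring with the open 2-aminoethyl chain gives large steps, an 11-fold higher number from compound 3 to compound 4 (1.04 log units; beyond the scatter) and a 13-fold higher number from compound 1 to compound 4 (1.10 log units; beyond the scatter), whereas changes of ring size gave modest steps or none beyond the scatter. Even the pyrrolidin-3-yl compound keeps an edge over the open chain, with a 2.4-fold higher number from compound 2 to compound 4 (0.39 log units; beyond the scatter), which makes compound 4 the weakest of the four. No evidence is available to explain this loss.

From the compounds shown here alone, it remains open whether a longer chain, such as 3-aminopropyl, would return to the numbers of the larger rings. Going by these compounds, the effect of a dimethylamino group at the chain end also remains open.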